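The source may hold more compounds than are shown below. What is called first, only, known or untested is meant among the compounds shown, and "the series" means these compounds.

Measured so far in a functional assay on HCT-15 cells (Homo sapiens) for antiproliferative activity, read by sulforhodamine B assay; a higher number here means a weaker inhibitor of growth, a lower number a stronger inhibitor of growth:
- compound 1 `O=C(/C=C/c1ccc(O)cc1)c1c(O)cccc1OCC1CCCC1`: 3410 nM
- compound 2 `O=C(/C=C/c1ccc(O)cc1)c1c(O)cccc1OCc1ccccc1`: > 30000 nM

Compound 2 has only a limit in this assay, not a number: > 30000 nM.

Compound 3 `O=C(/C=C/c1ccc(O)cc1)c1c(O)cccc1OCCC1CCCC1` carries cyclopentylmethyl in place of phenyl on a saturated chain carbon bound to an oxygen on an aromatic ring.

Among the measured compounds shown here, one measured step bears on this change: an at least 8.7-fold higher number from compound 1 to compound 2 (0.94 log units; beyond the scatter), where phenyl replaced cyclopentyl. Returning to a saturated ring should therefore reverse that step, giving a lower number of similar size. For the measured compounds named here, no measured compound carries the 2-cyclopentylethyl group, so the range stays wide.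

The step expected is an at least 6.6-fold lower number from compound 2 to compound 3 (0.82 log units; beyond the scatter).

For compound 3 the estimated value is 4500 nM, with an expected range of 1500 nM to 15000 nM.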

Compound 3, concentration for 50% growth inhibition: 3310 nM
The estimate for compound 3 lay 1.4-fold (0.13 log units) above the measured number; the range from low to high includes it.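

In this assay, cyclopentylmethyl in place of phenyl gives an at least 9.0-fold lower number from compound 2 to compound 3 (0.95 log units; beyond the scatter). Compound 2 has a limit rather than a number, so this step has no exact size: the limit of > 30000 nM in this assay, at which 1 of the 3 values shown sits. Cyclopentylmethyl in place of cyclopentyl gives a 1.0-fold lower number from compound 1 to compound 3 (0.01 log units; within the scatter), so the two groups with a saturated ring cannot be told apart here, and only compound 2, with its aromatic ring, stands apart.

Still open, on these data alone, is whether a 2-phenylethyl group, with an aromatic ring on the longer chain, would match compound 2 or compound 3. A cyclohexyl ring or a still longer chain also remains to be placed.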